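Phenyl in Place of Cyclohexyl across Two Cores

A few compounds are considered here, and "the series" means these few. Any claim that something is new, unique, unknown or untested is made for them only; others in the source may bear on it.

Compound 1 `C[C@@H](Nc1nc(O)c2cc(Cl)ccc2n1)C1CCCCC1`: 5600 nM
Compound 2 `C[C@@H](Nc1nc(O)c2cc(Cl)ccc2n1)c1ccccc1`: 2800 nM
Compound 3 `Oc1nc(NCC2CCCCC2)nc2ccc(I)cc12`: 3900 nM

All three were tested in a functional assay (aorta) for inhibition, with Rattus norvegicus as the target; on this read-out lower numbers stand for stronger inhibition and higher numbers for weaker inhibition. Compound 1 and compound 2 share a core and differ by phenyl in place of cyclohexyl on a saturated chain carbon bound to a nitrogen on an aromatic ring and a saturated chain carbon; the step is a 2.0-fold lower number from compound 1 to compound 2 (0.30 log units; within the scatter). Compound 3 lies close to both, within the scatter of each. How its core differs from that of compound 1 is not broken down here. Compound 4 `Oc1nc(NCc2ccccc2)nc2ccc(I)cc12` is unmeasured and differs from compound 3 by phenyl in place of cyclohexyl on a saturated chain carbon bound to a nitrogen on an aromatic ring. This is the same kind of change as that from compound 1 to compound 2, not the same: there the place was a saturated chain carbon bound to a nitrogen on an aromatic ring and a saturated chain carbon, here a saturated chain carbon bound to a nitrogen on an aromatic ring. Because a 2.0-fold lower number from compound 1 to compound 2 (0.30 log units; within the scatter) stayed within the scatter, a step of similar size is expected, a 1.8-fold lower number from compound 3 to compound 4 (0.25 log units; within the scatter). Compound 4 is thus estimated at 2200 nM in this assay, probably between 800 nM and 6000 nM.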

Compound 4, half-maximal inhibitory concentration: 1400 nM
Estimate against measurement, compound 4: 1.6-fold (0.20 log units) above, within the range that was stated.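

In this assay, phenyl in place of cyclohexyl gives a 2.8-fold lower number from compound 3 to compound 4 (0.44 log units; beyond the scatter), a modest step that lies beyond the scatter. The same change lowers the number on both cores, and the sizes of the two steps cannot be told apart: the same change on two cores in this assay, a 2.0-fold lower number (0.30 log units; within the scatter) from compound 1 to compound 2 and a 2.8-fold lower number (0.44 log units; beyond the scatter) from compound 3 to compound 4, 1.4-fold (0.14 log units) apart, within the scatter of two such steps. Among the compounds shown here, this supports carrying the change between these two cores, but two pairs show nothing about any other core, and only the step on the core of compound 3 stands clear of the scatter on its own.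

As far as these compounds go, it remains open whether a longer chain in place of the phenyl would lower the number further. The same question stands for a phenyl ring carrying an amine or a carboxylic acid.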